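Amino for Hydroxy on the Benzyl Group of Compound 1

A few compounds are considered here, and "the series" means these few. Any claim that something is new, unique, unknown or untested is made for them only; others in the source may bear on it.

Of the compounds shown here, three built on a shared core have been measured in a functional assay on Hep 3B2 cells (Homo sapiens) for antiproliferative activity, read by MTT assay, with a stated time of 72 h; a higher number here means a weaker inhibitor, a lower number a stronger inhibitor. Compound 1 `COc1cccc(CNCc2c(C(=O)O)n(Cc3ccc(O)cc3)c3cc(C(C)C)ccc23)c1` gives 5340 nM in this assay. Going by the values given here, compound 2 `COc1cccc(CNCc2c(C(=O)O)n(Cc3ccccc3)c3cc(C)ccc23)c1` gives 7310 nM, a number that sits within the scatter of the one for compound 1, so the two cannot be told apart. Compound 3 `COc1ccc(Cn2c(C(=O)O)c(CNCc3cccc(O)c3)c3ccc(C)cc32)cc1` gives 11800 nM, which lies beyond the scatter above the number for compound 1. Compound 1 therefore stands at the low end of the three numbers, although its gap to compound 2 is not a real one.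

The step followed here leads from compound 1 to compound 4 `COc1cccc(CNCc2c(C(=O)O)n(Cc3ccc(N)cc3)c3cc(C(C)C)ccc23)c1`, which has not been measured. The change is amino in place of hydroxy on an aromatic carbon. One heavy atom leaves and one enters, and the count of hydrogen-bond donors and acceptors is unchanged. Among the compounds with values here, no pair of measured compounds differs in only one place, so no measured step of this kind exists. A swap from 4-hydroxybenzyl to 4-aminobenzyl is expected to move the number little, and the step of a 1.0-fold higher number from compound 1 to compound 4 (0.01 log units; within the scatter) is expected to stay within the scatter, in no particular direction. Compound 4 is estimated at 5500 nM, with a range from 2200 nM to 14000 nM.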

Compound 4, half-maximal inhibitory concentration: 11300 nM
For compound 4 the middle estimate is 2.1-fold (0.31 log units) below the measured one; low and high end bracket the measured number.
By their numbers in this assay, from the lowest: compounds 1, 2, 4 and 3 (each within the scatter of the next, the first and the last beyond it).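

In this assay, the swap of 4-hydroxybenzyl to 4-aminobenzyl gives a 2.1-fold higher number from compound 1 to compound 4 (0.33 log units; beyond the scatter), the only step shown that changes a single place, and this step lies beyond the scatter. The aromatic carbon para to a large group therefore does not treat these two groups alike, even though they are matched in heavy-atom count and in hydrogen-bond donors and acceptors, and the hydroxy group of compound 1 is the better of the two here by a modest margin. No supporting measurement is available to explain why this exchange costs activity.

The compounds shown leave open whether the step reflects something the hydroxy group adds or something the amino group takes away, as an unsubstituted benzyl group on the core of compound 1 would be needed to separate the two. They also leave open how other groups at this place, such as a fluorine atom, an acetamide or a carboxylic acid, would compare, and whether the same exchange would give a similar step on other versions of the shared core.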